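Ester chain extension on the thiophen-3-yl thioxo-dihydropyrimidine ester

A few compounds are considered here, and "the series" means these few. Any claim that something is new, unique, unknown or untested is made for them only; others in the source may bear on it.

Measured so far in an assay on membranes from CHO cells for displacement of a labelled ligand from adenosine receptor A1 (Homo sapiens), read by scintillation counting, with a stated time of 60 min, tested at 1 uM; on this read-out lower numbers stand for less inhibition and higher numbers for more inhibition at the one concentration tested (going by the name of the read-out):
compound 1 `CC1=C(C(=O)OCC(C)C)C(c2ccco2)NC(=S)N1` gives 7%
compound 2 `COC(=O)C1=C(C)NC(=S)NC1c1ccoc1` gives 25%
compound 3 `COC(=O)C1=C(C)NC(=S)NC1c1ccsc1` gives 3%

Compound 3 stands lowest of the three numbers. Among the compounds with values here, its nearest neighbour is compound 1, which sits within the scatter of it, so no order between those two can be read; compound 2 stands furthest away, beyond the scatter, and the only single-place step recorded is a number 22 percentage points lower from compound 2 to compound 3 (beyond the scatter).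

Compound 4 `CC1=C(C(=O)OCC(C)C)C(c2ccsc2)NC(=S)N1` is the next compound. It differs from compound 3 as isopropyl in place of hydrogen on a saturated chain carbon bound to an oxygen next to a carbonyl group. Within the data shown here, no measured pair differs from another in this one place, so the recorded step does not bear on it; the only indirect hint is that compound 1, which carries the same isobutyl ester, also gives a low number. For compound 4 the expectation is therefore no change beyond the scatter, with the estimated step of a number 3 percentage points higher from compound 3 to compound 4 (within the scatter). Compound 4 is estimated at 6%, in a range from 0% to 18%.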

Compound 4, a percentage reported as inhibition, at one concentration (the size of the read-out at that concentration, not a potency): 8%
The estimate for compound 4 lay 2 percentage points below the measured number, within the range that was stated.
By their numbers in this assay, from the lowest: compounds 3, 1 and 4 (each within the scatter of the next); then compound 2.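

Methoxy to isobutoxy, that is isopropyl in place of hydrogen on a saturated chain carbon bound to an oxygen next to a carbonyl group, gives in this assay a number 5 percentage points higher from compound 3 to compound 4 (within the scatter) and so brings no readable change with thiophen-3-yl in the series. With the isobutyl ester held, thiophen-3-yl in place of furan-2-yl gives a number 1 percentage points higher from compound 1 to compound 4 (within the scatter) and the two groups cannot be told apart, whereas the methyl ester pair with furan-3-yl shows a number 22 percentage points lower from compound 2 to compound 3 (beyond the scatter) as a step beyond the scatter. No measurement offers a reason for either result.

Open, going by these compounds, is whether furan-3-yl keeps the number of compound 2 at 25% when it carries the isobutyl ester. Also open, on these data alone, is whether a longer chain, an amide or a carboxylic acid at the ester position would move the number beyond the scatter.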